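Aryl variation on the triazole and the cytotoxicity read-out

A few compounds are considered here, and "the series" means these few. Any claim that something is new, unique, unknown or untested is made for them only; others in the source may bear on it.

Compound 1 `C/C(=C\CC/C(C)=C/CC[C@@H]1[C@@]2(C)CCC(=O)C(C)(C)[C@H]2CC[C@@]1(C)O)CC/C=C(\C)C(=O)OCc1cn(-c2cccc(O)c2)nn1`: 146000 nM
Compound 2 `C/C(=C\CC/C(C)=C/CC[C@@H]1[C@@]2(C)CCC(=O)C(C)(C)[C@H]2CC[C@@]1(C)O)CC/C=C(\C)C(=O)OCc1cn(-c2ccccc2C(F)(F)F)nn1`: > 150000 nM, a limit of the assay
Compound 3 `C/C(=C\CC/C(C)=C/CC[C@@H]1[C@@]2(C)CCC(=O)C(C)(C)[C@H]2CC[C@@]1(C)O)CC/C=C(\C)C(=O)OCc1cn(-c2ccc(F)c(Cl)c2)nn1`: > 150000 nM, a limit of the assay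

In an ADME assay on L132 cells (Homo sapiens) for cytotoxicity, read by MTT assay, with a stated time of 48 h (on this read-out lower numbers stand for stronger inhibition and higher numbers for weaker inhibition), compound 3 stands at the limit rather than at a number, the limit being (the limit of > 150000 nM in this assay, at which 2 of the 3 values shown sit). Compound 2 also returns only that limit. The measured steps are small: an at least 1.0-fold higher number from compound 1 to compound 2 (0.01 log units; that floor lies within the scatter) and an at least 1.0-fold higher number from compound 1 to compound 3 (0.01 log units; that floor lies within the scatter), while a step that the two limits leave unreadable from compound 2 to compound 3. The change to compound 4 `C/C(=C\CC/C(C)=C/CC[C@@H]1[C@@]2(C)CCC(=O)C(C)(C)[C@H]2CC[C@@]1(C)O)CC/C=C(\C)C(=O)OCc1cn(-c2ccccc2[N+](=O)[O-])nn1` is 2-nitrophenyl in place of 3-chloro-4-fluorophenyl on an aromatic nitrogen. Going by the values given here, only the steps from compound 1 bear on it, and neither reaches beyond the scatter, so no step beyond the scatter is expected in this assay in either direction, and the read-out for compound 4 will likely again be a limit. Compound 4 is estimated at 150000 nM, within 90000 nM to 300000 nM. The expected step is a number no higher from compound 3 to compound 4 (the limit leaves the size open).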

Compound 4, half-maximal inhibitory concentration: > 150000 nM
Compound 4 gave a limit, no number; the forecaster's own chance of this, stated with the estimate: 65%; the middle value lies on the limit itself.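

In this assay compound 4 is a third aryl variant that returns only a limit, and the limit now spans 2-nitrophenyl as well as 2-(trifluoromethyl)phenyl and 3-chloro-4-fluorophenyl: the limit of > 150000 nM in this assay, at which 3 of the 4 values shown sit. Going by these compounds alone, the one readable step is an at least 1.0-fold higher number from compound 1 to compound 4 (0.01 log units; that floor lies within the scatter), so 2-nitrophenyl in place of 3-hydroxyphenyl shows no change beyond the scatter. The steps among compound 2, compound 3 and compound 4 cannot be read, since both ends of each are limits.

Still open, on these data alone, is whether any group on this aromatic nitrogen gives a number clearly lower than that of compound 1. An aminophenyl, a carboxyphenyl or a longer alkyl chain there would test this.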